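The source may hold more compounds than are shown below. What is called first, only, known or untested is meant among the compounds shown, and "the series" means these compounds.

Compound 1, `Cc1ccc(-c2cn(-c3ccc(CN4CCN(C)CC4)cc3)nn2)cc1Nc1nccc(-c2cccnc2)n1`, gives 6160 nM in a functional assay on KG-1a cells (Homo sapiens) for inhibition, read by MTT assay, with a stated time of 72 h (a higher number here means a weaker inhibitor, a lower number a stronger inhibitor), the highest of the two numbers recorded so far. Its nearest neighbour is compound 2, `Cc1ccc(-c2cn(-c3ccc(CN4CCN(C)CC4)c(C(F)(F)F)c3)nn2)cc1Nc1nccc(-c2cccnc2)n1`, which gives 1040 nM; the step from one to the other, a 5.9-fold lower number from compound 1 to compound 2 (0.77 log units; beyond the scatter), comes from trifluoromethyl in place of hydrogen on an aromatic carbon. Compound 3, `CCN(CC)c1ccc(-n2cc(-c3ccc(C)c(Nc4nccc(-c5cccnc5)n4)c3)nn2)cc1`, has not yet been measured in this assay. It differs from compound 1 at another site: diethylamino in place of (4-methylpiperazin-1-yl)methyl on an aromatic carbon. Among the measured compounds shown here, the single measured step concerns a different position and a different kind of exchange, so no recorded step bears directly on this change, and the account has nothing in hand on what the exchange does. The expectation for compound 3 is therefore a step of a 1.0-fold lower number from compound 1 to compound 3 (0.01 log units; within the scatter), that is, no change beyond the scatter, and compound 3 is estimated at 6000 nM, within a range of 1500 nM to 24000 nM.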

Compound 3, half-maximal inhibitory concentration: 2930 nM
Compound 3: the middle estimate sits 2.0-fold (0.31 log units) above what was measured; measured number inside the range.
By their numbers in this assay, from the lowest: compound 2; then compound 3; then compound 1.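

Compound 3 shows that in this assay the (4-methylpiperazin-1-yl)methyl group can be given up at this site, on an aromatic carbon para to a large group, without any loss: the exchange for diethylamino gives a 2.1-fold lower number from compound 1 to compound 3 (0.32 log units; beyond the scatter). Among the compounds shown here, the earlier step came from trifluoromethyl at another site, so this is the first sign that the group at this site itself moves the number, and that the six-membered non-aromatic ring is not needed for the inhibition seen here. Nothing at hand accounts for the size or direction of this step.

The compounds shown leave open whether the step follows from losing the ring or from losing the linking carbon, which a diethylaminomethyl group would help to separate. On these data alone, it also remains open whether a trifluoromethyl group on compound 3 would lower the number further.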